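Bromo to fluoro in a low-toxicity series

The source may hold more compounds than are shown below. What is called first, only, known or untested is meant among the compounds shown, and "the series" means these compounds.

Measured compounds:
compound 1 `O=C1Nc2ccccc2/C1=N/NC(=S)Nc1ccc(Br)cc1`: > 25000 nM
compound 2 `COc1cccc(NC(=O)N/N=C2\C(=O)Nc3ccccc32)c1`: > 25000 nM

In an ADME assay on RD cells (Homo sapiens) for cytotoxicity (on this read-out higher numbers stand for lower toxicity in this test and lower numbers for higher toxicity in this test), compound 1 gives > 25000 nM, which is a limit of the test and not a number. Compound 2 also gives only a limit in this assay, > 25000 nM. Compound 1 thus stands at the limit of > 25000 nM in this assay, at which 2 of the 2 values shown sit, so nothing separates it from compound 2 on the numbers shown. Compound 3 `O=C1Nc2ccccc2/C1=N/NC(=S)Nc1ccc(F)cc1` has not yet been tested in this assay. It differs from compound 1 by fluoro in place of bromo on an aromatic carbon. Going by the values given here, no measured pair isolates this change, so no step beyond the scatter is expected in either direction. The step expected in this assay is a step that the limit leaves unreadable from compound 1 to compound 3. Compound 3 is therefore estimated to give 40000 nM, with a range from 15000 nM to 150000 nM, most likely again reported only as a limit.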

Compound 3, half-maximal cytotoxic concentration: > 25000 nM
Compound 3 was reported as a limit; the forecaster's own chance of this, stated with the estimate: 80%; the middle value is on the limit's open side.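

In this assay compound 3 gives > 25000 nM, which is a limit of the assay and not a number, so no step can be read between compound 1 and compound 3. The compounds shown leave open whether fluoro in place of bromo changes this read-out at all, as all the values rest at one limit: the limit of > 25000 nM in this assay, at which 3 of the 3 values shown sit.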